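The compounds below may be only part of what the source reports. "The series", "measured", "known", "first", "only" and "open" are said of these compounds alone.

In an assay on CHO-TREX cells for antagonist activity at transient receptor potential cation channel subfamily A member 1 (Homo sapiens), read by FLIPR and calcium flux, with a stated time of 10 min (a lower number here means a stronger inhibitor, a higher number a weaker inhibitor), compound 1, with the structure `c1ccc(-c2ccc3[nH]ncc3c2)cc1`, gives only > 30000 nM, which is a limit of the assay rather than a measured number. This is the same boundary described by the limit of > 30000 nM in this assay, at which 1 of the 2 values shown sits. Among the compounds with values here, compound 2, with the structure `Fc1cc2[nH]ncc2cc1-c1ccccc1C(F)(F)F`, is the one compound here with a true number: in this assay compound 2 gives 48 nM. Within the data shown here, the one other value shown for the series, that of compound 1, is a limit of the assay rather than a number. Compound 2 therefore stands alone among the measured values.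

Compound 3, with the structure `CCc1cc2[nH]ncc2cc1-c1ccccc1C(F)(F)F`, differs from compound 2 in a single place: ethyl in place of fluoro on an aromatic carbon, sitting on the six-membered carbon-only ring of the fused system, ortho to a large group. Among the measured compounds shown here, no measured pair in this set shows what such an exchange does in this assay, so the size of the step is open. The expectation is a change that stays within, or only modestly beyond, the usual scatter, with a slight lean toward weaker inhibition, giving an estimated step from compound 2 to compound 3 of a 2.1-fold higher number from compound 2 to compound 3 (0.32 log units; beyond the scatter). For compound 3 the estimated value in this assay is 100 nM, expected to fall between 30 nM and 400 nM.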

Compound 3, half-maximal inhibitory concentration: 50 nM
Compound 3: the middle estimate sits 2.0-fold (0.30 log units) above what was measured, and the stated range covers the measured number.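

In this assay, ethyl in place of fluoro on this aromatic carbon, ortho to a large group, gives a 1.0-fold higher number from compound 2 to compound 3 (0.02 log units; within the scatter), so the two compounds cannot be told apart at this position. Within the data shown here, this is the first measured step at this place, and it shows that going from a fluoro group of 1 heavy atom to an ethyl group of 2 heavy atoms, with carbon entering where fluorine leaves, does not separate compound 3 from compound 2 in this read-out. It is a single pair, however, so it speaks only for these two groups on this core, and nothing measured here gives a reason for the result.

The compounds shown leave open what a longer chain such as propyl, a small ring such as cyclopropyl, or a group carrying an amine or a carboxylic acid would do on this carbon. Compound 1 differs from compound 2 and from compound 3 in more than one place, so what a plain hydrogen on this carbon does by itself, apart from the other difference, also stays unresolved.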